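The source may hold more compounds than are shown below. What is called first, only, known or untested is meant among the compounds shown, and "the series" means these compounds.

Of the compounds shown here, three sharing one core have been tested in a functional assay on MCF7 cells (Homo sapiens) for antiproliferative activity, read by MTT assay, with a stated time of 48 h; a lower number here means a stronger inhibitor, a higher number a weaker inhibitor. Compound 1 `N#CC1=C(N)Oc2c(c3nc4ccccc4nc3c3ccccc23)C12C(=O)N(Cc1cnnn1-c1ccccc1Cl)c1ccccc12` carries a 2-chlorophenyl on an aromatic nitrogen of a five-membered aromatic ring with 3 nitrogen. In this assay compound 1 returns only a limit, > 50000 nM. Compound 2 `N#CC1=C(N)Oc2c(c3nc4ccccc4nc3c3ccccc23)C12C(=O)N(Cc1cnnn1-c1cccc(Br)c1)c1ccccc12` has a 3-bromophenyl in place of that 2-chlorophenyl. In this assay compound 2 likewise gives only a limit, > 50000 nM. Compound 3 `CCOc1ccccc1-n1nncc1CN1C(=O)C2(C(C#N)=C(N)Oc3c2c2nc4ccccc4nc2c2ccccc32)c2ccccc21` bears a 2-ethoxyphenyl on the same nitrogen. In this assay compound 3 also stops at a limit, > 50000 nM. Because of the limit of > 50000 nM in this assay, at which 3 of the 3 values shown sit, none of the changes among these three can be sized: a step that the two limits leave unreadable from compound 1 to compound 2, a step that the two limits leave unreadable from compound 1 to compound 3 and a step that the two limits leave unreadable from compound 2 to compound 3 are all unreadable. Compound 3 thus stands at the edge of what the assay reports, and both its neighbours stand with it.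

Compound 4 `N#CC1=C(N)Oc2c(c3nc4ccccc4nc3c3ccccc23)C12C(=O)N(Cc1cnnn1-c1cccc(S(N)(=O)=O)c1)c1ccccc12` is not yet measured; its change from compound 3 is 3-sulfamoylphenyl in place of 2-ethoxyphenyl on an aromatic nitrogen. For the measured compounds named here, no measured step bears on this exchange in a readable way, and no value so far has left the limit. The expectation is that compound 4 also shows no measurable inhibition in this assay, estimated at 80000 nM with a range from 20000 nM to 300000 nM. The expected step is a step that the limit leaves unreadable from compound 3 to compound 4, which would not be distinguishable from no change.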

Compound 4, half-maximal inhibitory concentration: 42500 nM
Beside the measured number, compound 4's estimate is 1.9-fold (0.27 log units) above it, and the stated range covers the measured number.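

With the 3-sulfamoylphenyl on the aromatic nitrogen, compound 4 is the only compound shown that returns a number rather than a limit in this assay and so gives this position its first readable value. For the compounds shown here, exchanging the group gives three steps, (an at least 1.1-fold lower number from compound 3 to compound 4 (0.07 log units; that floor lies within the scatter)) and (an at least 1.1-fold lower number from compound 2 to compound 4 (0.07 log units; that floor lies within the scatter)) and (an at least 1.1-fold lower number from compound 1 to compound 4 (0.07 log units; that floor lies within the scatter)), and the one with the bromo group is the closest comparison, since only sulfamoyl in place of bromo on an aromatic carbon separates compound 2 from compound 4. From the compounds shown here alone, each step is only a floor that lies within the scatter, so the data do not establish that compound 4 differs from the other three, and the true sizes stay unknown because those three compounds give no number: the limit of > 50000 nM in this assay, at which 3 of the 4 values shown sit.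

The compounds shown leave open whether the readable value belongs to the sulfamoyl group specifically or whether another group on the same phenyl ring, such as a carboxylic acid or an amine, would also give a number. They also leave open whether any group at this position can bring the number far below the limit, and how much of any such change would survive a repeat of the measurement.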